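This account rests on a few compounds, and the source may have more. Where it says the series, first, only, none or still open, it means among the compounds named here.

Compound 3 `O=C(CCCc1ccc(Cl)cn1)N1CCc2c(Cl)c(O)c(O)c(Cl)c2C1` carries a chloro group on its six-membered aromatic ring with 1 nitrogen. In a functional assay (Homo sapiens), tested at 1 uM (on this read-out lower numbers stand for a stronger effect and higher numbers for a weaker effect at the one concentration tested), compound 3 gives 85%, the second highest of the three values measured. Compound 1 `O=C(CCCc1ccc(F)cn1)N1CCc2c(Cl)c(O)c(O)c(Cl)c2C1` gives 89%, and compound 2 `O=C(CCCc1ccc([N+](=O)[O-])cn1)N1CCc2c(Cl)c(O)c(O)c(Cl)c2C1` gives 74%. The step of a number 4 percentage points lower from compound 1 to compound 3 (within the scatter) shows chloro and fluoro behave alike, while a number 11 percentage points higher from compound 2 to compound 3 (beyond the scatter) shows a modest shift. Compound 4 `COc1ccc(CCCC(=O)N2CCc3c(Cl)c(O)c(O)c(Cl)c3C2)nc1` differs from compound 3 by methoxy in place of chloro on an aromatic carbon. Among the measured compounds shown here, no measured step introduces methoxy, so only the two steps ending at compound 3 guide the expectation, and both are small. Compound 4 is therefore expected to shift by about a number 1 percentage points lower from compound 3 to compound 4 (within the scatter), nothing beyond the scatter. Compound 4 is estimated at 84%, with a range from 70% to 96%.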

Compound 4, a percentage reported as activity, at one concentration (the size of the read-out at that concentration, not a potency): 96%
Estimate against measurement, compound 4: 12 percentage points below, within the range that was stated.
By their numbers in this assay, from the lowest: compound 2; then compounds 3, 1 and 4 (each within the scatter of the next, the first and the last beyond it).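

In this assay, methoxy in place of chloro gives a number 11 percentage points higher from compound 3 to compound 4 (beyond the scatter), and methoxy in place of nitro gives a number 22 percentage points higher from compound 2 to compound 4 (beyond the scatter), so a group with an oxygen on this carbon does not by itself bring the lower number seen with nitro. Methoxy in place of fluoro gives a number 7 percentage points higher from compound 1 to compound 4 (within the scatter), so these two groups cannot be told apart here, and compound 2 remains the only clear outlier. Nothing available explains these differences. From the compounds shown here alone, how an amine or a carboxylic acid at this position would read remains open.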